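Swapping the Aryl Group on a Shared Core

This account rests on a few compounds, and the source may have more. Where it says the series, first, only, none or still open, it means among the compounds named here.

Of the compounds shown here, two with the same core have been measured in a functional assay on KB cells (Homo sapiens) for cytotoxicity, read by MTT assay, with a stated time of 72 h; on this read-out higher numbers stand for an effect only at larger amounts of compound and lower numbers for an effect already at smaller amounts. Compound 1, with structure `O=C1/C(=C\c2ccc(O)cc2)c2ccccc2N1c1c(Cl)cccc1Cl`, gives 2 ug/mL. Compound 2, with structure `O=C1/C(=C\c2ccccc2[N+](=O)[O-])c2ccccc2N1c1c(Cl)cccc1Cl`, gives 1 ug/mL. Of these two numbers, compound 2 has the lower one, but the gap to compound 1 is small: the change a 2.0-fold lower number from compound 1 to compound 2 (0.30 log units; within the scatter) lies within the scatter, so the two compounds cannot be told apart on this read-out.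

Compound 3, with structure `O=C1/C(=C\c2ccc(Cl)cc2)c2ccccc2N1c1c(Cl)cccc1Cl`, has not yet been measured. It differs from compound 2 in one place: 4-chlorophenyl in place of 2-nitrophenyl on a double-bonded chain carbon bound to a double-bonded ring carbon.

Within the data shown here, no measured step covers this particular exchange. Among the measured compounds shown here, the only step that bears on it, the exchange of one aryl group for another in a 2.0-fold lower number from compound 1 to compound 2 (0.30 log units; within the scatter), produced no difference beyond the scatter. On that basis no step beyond the scatter is expected for compound 3 either, in either direction, as a 1.5-fold higher number from compound 2 to compound 3 (0.18 log units; within the scatter).

Compound 3 is therefore estimated to give about 1.5 ug/mL in this assay, with a range from 0.5 ug/mL to 4 ug/mL.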

Compound 3, concentration for half-maximal effect: 2 ug/mL
Compound 3: middle estimate off by 1.3-fold (0.12 log units), on the low side, within the range that was stated.
By their numbers in this assay, from the lowest: compounds 2, 1 and 3 (each within the scatter of the next).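

In this assay, the step of a 2.0-fold higher number from compound 2 to compound 3 (0.30 log units; within the scatter) shows that at this place on a double-bonded chain carbon bound to a double-bonded ring carbon, a group with hydrogen-bond acceptors can give way to 4-chlorophenyl, which has none, with a result that stays within the scatter. The step of no change at the digits printed from compound 1 to compound 3 (within the scatter) adds a narrower comparison, since only chloro in place of hydroxy on an aromatic carbon separates the two compounds, and this exchange also stays within the scatter, so compounds 1, 2 and 3 cannot be told apart on this read-out. Nothing measured here offers an explanation for these results.

All three compounds carry a six-membered aromatic ring of carbon only at this place, so the compounds shown leave open whether the read-out would stay the same with a ring that contains nitrogen, such as pyridine, or with an open alkyl chain instead. On these data alone, it also remains open how a carboxylic acid or an amine on the aromatic ring would read in this assay.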